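Loss of 1,3-thiazol-2-yl from a sulfonamide nitrogen

The source may report more compounds than this note shows. Statements on the series, on what has been measured and on what is new or still open speak of the compounds shown alone.

- compound 1 `O=S(=O)(Nc1nccs1)c1ccc(Nc2nncc3ccccc23)cc1` gives 54 nM
- compound 2 `COc1ccc(NC(=S)NNc2nncc3ccccc23)cc1` gives 94 nM

In a functional assay on K562 cells (Homo sapiens) for antiproliferative activity, read by sulforhodamine B assay, with a stated time of 72 h (a higher number here means a weaker inhibitor, a lower number a stronger inhibitor), compound 1 (54 nM) holds the lowest of the two numbers, yet compound 2 (94 nM) lies within the scatter of it, so neither stands apart. Compound 3 (`NS(=O)(=O)c1ccc(Nc2nncc3ccccc23)cc1`) differs from compound 1 by hydrogen in place of 1,3-thiazol-2-yl on a sulfonamide nitrogen. Going by the values given here, no measured pair shows this change, so the expectation rests on the change alone. The step expected in this assay runs toward a higher number (a 2.4-fold higher number from compound 1 to compound 3 (0.38 log units; beyond the scatter)). For compound 3 the estimated value is 130 nM (range 35 nM to 500 nM).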

Compound 3, half-maximal inhibitory concentration: 14 nM
For compound 3 the middle estimate is 9.3-fold (0.97 log units) above the measured one, and the stated range ends above it.
By their numbers in this assay, from the lowest: compound 3; then compounds 1 and 2 (each within the scatter of the next).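

In this assay, hydrogen in place of 1,3-thiazol-2-yl on a sulfonamide nitrogen gives a 3.9-fold lower number from compound 1 to compound 3 (0.59 log units; beyond the scatter) and so runs toward the stronger inhibitor. At this position, the 1,3-thiazol-2-yl group is therefore not required for antiproliferative activity, and the sulfonamide nitrogen bearing only hydrogen gives the lowest number of the three compounds. No available evidence bears on why the step runs this way. This single pair leaves open how a small group such as methyl or acetyl on the same nitrogen would read. It also leaves open whether a six-membered ring such as pyridin-2-yl would behave like 1,3-thiazol-2-yl.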